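The source may report more compounds than this note shows. Statements on the series, on what has been measured and on what is new or still open speak of the compounds shown alone.

Compound 3 `CCOCCOc1cccc2ccc(N)nc12` stands at the limit of an assay on cells with melanin-concentrating hormone receptor 1 (Homo sapiens) as the target, read by radioligand binding (on this read-out higher numbers stand for weaker inhibition and lower numbers for stronger inhibition), with > 2000 nM, a limit of the assay rather than a measured number. Compound 2 `CC(CC(C)(C)C)Oc1cccc2cccnc12` likewise returns only a limit, > 2000 nM. For the measured compounds named here, compound 1 `CC1CCCCC1Oc1cccc2ccc(N)nc12` is the one member of the set with a number, 32 nM; the limit of > 2000 nM in this assay, at which 2 of the 3 values shown sit, marks where two of the three values sit. Compound 4 `CCCCOc1cccc2ccc(N)nc12` differs from compound 3 by ethyl in place of ethoxy on a saturated chain carbon, two bonds along the chain from an oxygen on an aromatic ring. Going by the values given here, no measured pair isolates this change, so the direction is read from compound 1, which on the shared core gives 32 nM in this assay. For compound 4 a gain of an at least 2.5-fold lower number from compound 3 to compound 4 (0.39 log units; beyond the scatter) is expected, carrying it into measurable territory. The estimate for compound 4 is 800 nM, with a range from 150 nM to 4000 nM.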

Compound 4, half-maximal inhibitory concentration: 789 nM
Estimate against measurement, compound 4: 1.0-fold (0.01 log units) above; the range from low to high includes it.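

In this assay, ethyl in place of ethoxy on a saturated chain carbon, two bonds along the chain from an oxygen on an aromatic ring, gives an at least 2.5-fold lower number from compound 3 to compound 4 (0.40 log units; beyond the scatter). For the compounds shown here, this is the first readable step at this position, and it shows that the chain can carry ethyl instead of ethoxy and return a measured value. The full size of the step stays unknown, since compound 3 rests on a limit of the assay: the limit of > 2000 nM in this assay, at which 2 of the 4 values shown sit.

From the compounds shown here alone, whether a longer chain would lower the number further stays open. Also open, going by these compounds, is how an unsubstituted cyclohexyl group would compare with compound 1 at 32 nM.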